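A few compounds are considered here, and "the series" means these few. Any claim that something is new, unique, unknown or untested is made for them only; others in the source may bear on it.

Working notes on the series.

For the measured compounds named here, compound 1 `Cc1nccn1-c1cnc(NCc2c(F)ccc3c2CCO3)c2cn[nH]c(=O)c12` gives 7000 nM in a physicochemical assay for solubility, read by LC-MS, in phosphate buffer, with a stated time of 24 h, at pH 7.4 (a lower number here means a less soluble compound, a higher number a more soluble compound), which is the lowest of the two numbers measured so far. Going by the values given here, compound 2 `COCCC(=O)Nc1cnc(NCc2c(F)ccc3c2CCO3)n2cnnc12`, built on a different core, gives 980000 nM in this assay; the gap between compound 1 and compound 2 lies beyond the scatter, but no single-point step connects the two, so only the two numbers themselves are noted.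

Compound 3 `Cc1ncccc1-c1cnc(NCc2c(F)ccc3c2CCO3)c2cn[nH]c(=O)c12` is the next compound and differs from compound 1 in one place: 2-methylpyridin-3-yl in place of 2-methyl-1H-imidazol-1-yl on an aromatic carbon. One five-membered aromatic ring with 2 hetero atoms and 2 hydrogen-bond acceptors is traded for one six-membered aromatic ring with 1 hetero atom and 1 hydrogen-bond acceptor, at the same attachment point on the shared core. Among the compounds with values here, no measured step of this kind exists to lean on. The expectation is a modest downward step in this assay, close to or just beyond the scatter, as a 2.0-fold lower number from compound 1 to compound 3 (0.30 log units; within the scatter). For compound 3 the estimate in this assay is 3500 nM, with a range of 900 nM to 15000 nM.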

Compound 3, solubility: < 2000 nM
Compound 3: a limit, no number (the forecaster's own chance of this, stated with the estimate: 5%); middle value at least 1.7-fold (0.24 log units) away from the limit.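

For the compounds shown here, the swap of 2-methyl-1H-imidazol-1-yl for 2-methylpyridin-3-yl on this aromatic carbon gives the first single-point step, an at least 3.5-fold lower number from compound 1 to compound 3 (0.54 log units; beyond the scatter) in this assay. Going by these compounds alone, this shows that the read-out at this position responds to the group attached to the shared core, which the gap between compound 1 and compound 2 could not show, as no single-point step connects them. Compound 3 stands as a limit of the assay and not as a number: the limit of < 2000 nM in this assay, at which 1 of the 3 values shown sits.

From the compounds shown here alone, how far compound 3 lies past its limit stays open, and this single swap changes ring size and hetero atom count together, so the two cannot be separated. Also open, going by these compounds, is how an amine, a carboxylic acid or a longer chain on this aromatic carbon would read in this assay.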